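Nitro in place of bromo on the phenoxy ring

A few compounds are considered here, and "the series" means these few. Any claim that something is new, unique, unknown or untested is made for them only; others in the source may bear on it.

Compound 3 `CC(C)(Oc1ccccc1Br)C1OCC(C/C=C\CCC(=O)O)C(c2cccnc2)O1` gives 7000 nM in an assay for inhibition of prostacyclin synthase (Homo sapiens), using microsomes (on this read-out higher numbers stand for weaker inhibition and lower numbers for stronger inhibition), the highest of the two numbers at hand; compound 1 `CSc1ccc(OC(C)(C)C2OCC(C/C=C\CCC(=O)O)C(c3cccnc3)O2)c([N+](=O)[O-])c1` lies within the scatter of it at 5000 nM. Compound 2 `CC(C)(Oc1ccccc1F)C1OCC(C/C=C\CCC(=O)O)C(c2cccnc2)O1` reaches only a limit in this assay, < 1000 nM (the limit of < 1000 nM in this assay, at which 1 of the 3 values shown sits). Compound 4 `CC(C)(Oc1ccccc1[N+](=O)[O-])C1OCC(C/C=C\CCC(=O)O)C(c2cccnc2)O1` carries nitro in place of bromo on an aromatic carbon. For the measured compounds named here, the one measured step at this position is an at least 7.0-fold higher number from compound 2 to compound 3 (0.84 log units; beyond the scatter), so substituent changes here have moved the numbers. Compound 1 also bears a nitro group on that ring, with a methylthio group added; its value stands close to that of compound 3. The estimated step is a 1.8-fold lower number from compound 3 to compound 4 (0.24 log units; within the scatter). Compound 4 is expected at 4000 nM, within 1500 nM to 10000 nM.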

Compound 4, half-maximal inhibitory concentration: < 1000 nM
Compound 4 gave a limit, no number; the forecaster's own chance of this, stated with the estimate: 10%; at least 4.0-fold (0.60 log units) between middle value and limit.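

In this assay, nitro in place of bromo on the aromatic carbon gives an at least 7.0-fold lower number from compound 3 to compound 4 (0.84 log units; beyond the scatter), so this position separates nitro from bromo as well as fluoro from bromo. Hydrogen in place of methylsulfanyl gives an at least 5.0-fold lower number from compound 1 to compound 4 (0.69 log units; beyond the scatter), so the nitro group alone does not carry the high number of compound 1. Compound 4 gives a limit, not a number, as does compound 2, so the step between them cannot be read: the limit of < 1000 nM in this assay, at which 2 of the 4 values shown sit.

Going by these compounds, how far compound 2 and compound 4 lie past that limit stays open. Also open, on these data alone, is whether an amine or a methoxy group at this position would track with fluoro and nitro or with bromo.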